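Methyl on the anilino ring of compound 2

The source may report more compounds than this note shows. Statements on the series, on what has been measured and on what is new or still open speak of the compounds shown alone.

In a functional assay on MCF7 cells (Homo sapiens) for inhibition, read by sulforhodamine B assay (a higher number here means a weaker inhibitor, a lower number a stronger inhibitor), compound 2 `O=C1C(Nc2ccccc2)=CC(=O)c2c1nc1n2[C@H]2OC[C@@H](O)[C@H]2OC1` gives > 4000 nM as a limit of the assay and not a number. Compound 4 `Cc1ccc(NC2=CC(=O)c3c(nc4n3[C@H]3OC[C@@H](O)[C@H]3OC4)C2=O)cc1` differs from it by methyl in place of hydrogen on an aromatic carbon (methyl in place of hydrogen on an aromatic carbon, or phenyl to 4-methylphenyl). Compound 1 `CCCc1ccc(NC2=CC(=O)c3nc4n(c3C2=O)[C@H]2OC[C@@H](O)[C@H]2OC4)cc1` gives 4660 nM in this assay and compound 3 `O=C1C=C(Nc2ccccc2F)C(=O)c2c1nc1n2[C@H]2OC[C@@H](O)[C@H]2OC1` gives 3640 nM in the same read-out. Within the data shown here, with a 1.3-fold lower number from compound 1 to compound 3 (0.11 log units; within the scatter) as the only measured change of the group on the amine nitrogen, no step beyond the scatter is expected in this assay for the added methyl. That guide is a loose one, since compound 1 and compound 3 hold their core carbonyls in a different arrangement from compound 2 and compound 4. The expected step is a step that the limit leaves unreadable from compound 2 to compound 4 and it remains uncertain, as the starting point is only a limit. The estimate for compound 4 is 4300 nM with an expected range of 2200 nM to 8500 nM in this series.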

Compound 4, half-maximal inhibitory concentration: > 4000 nM
Compound 4 ended at the assay's limit; the forecaster's own chance of this, stated with the estimate: 35%; the middle value lies beyond the limit too.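

No step can be read from compound 2 to compound 4 in this assay, since both values are limits of the assay and not numbers: the limit of > 4000 nM in this assay, at which 2 of the 4 values shown sit.

The compounds shown leave open what methyl in place of hydrogen on an aromatic carbon does to inhibition, and where compound 2 and compound 4 truly stand.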